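This account rests on a few compounds, and the source may have more. Where it says the series, first, only, none or still open, it means among the compounds named here.

Series notes. Compound 3 `CCc1ccc(NC(=O)N(Cc2cc(OC)c(OC)c(OC)c2)n2cnnc2)cc1` is one of two compounds with a number rather than a limit: in a functional assay on MDA-MB-231 cells (Homo sapiens) for cytotoxicity, read by MTT assay, with a stated time of 48 h (on this read-out higher numbers stand for weaker inhibition and lower numbers for stronger inhibition), compound 3 gives 24800 nM. Compound 1 `COc1ccc(CN(C(=O)Nc2ccc(F)c(Cl)c2)n2cnnc2)cc1OC` lies within the scatter of it, since in this assay compound 1 gives 27900 nM. Compound 2 `COc1ccc(CN(C(=O)Nc2ccc(C)cc2)n2cnnc2)cc1OC` reaches only a limit of the assay, for in this assay compound 2 gives > 50000 nM. One of the three values therefore sits at the limit of > 50000 nM in this assay, at which 1 of the 3 values shown sits. Compound 4 `COc1cc(CN(C(=O)Nc2ccc(C)cc2)n2cnnc2)cc(OC)c1OC` differs from compound 3 by hydrogen in place of methyl on a saturated chain carbon bound to an aromatic carbon, that is (4-ethylphenyl)amino to (4-methylphenyl)amino. Within the data shown here, the only measured step that bears on it is an at least 1.7-fold higher number from compound 1 to compound 2 (0.25 log units; that floor lies within the scatter), where the 4-methylphenyl partner went to a weaker number. Compound 4 shares that 4-methylphenyl group, so an upward step is expected, read as a 1.8-fold higher number from compound 3 to compound 4 (0.26 log units; within the scatter). Compound 4 is estimated at 45000 nM, in the range 20000 nM to 100000 nM, with a fair chance of a limit only.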

Compound 4, half-maximal inhibitory concentration: > 50000 nM
Compound 4 ended at the assay's limit; the forecaster's own chance of this, stated with the estimate: 45%; at least 1.1-fold (0.04 log units) between middle value and limit.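

In this assay, methyl giving way to hydrogen on the saturated chain carbon gives an at least 2.0-fold higher number from compound 3 to compound 4 (0.30 log units; that floor lies within the scatter), so the measured number of compound 3 does not survive the change from 4-ethylphenyl to 4-methylphenyl, although the floor of the step does not clear the scatter. The step between compound 2 and compound 4 cannot be read, and both 4-methylphenyl compounds end at a limit: the limit of > 50000 nM in this assay, at which 2 of the 4 values shown sit. From the compounds shown here alone, how far the number of compound 3 could fall with a longer chain such as propyl, or with an amine, at this place stays open.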